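Swapping One Dihydroxyphenyl Group of Compound 3

A few compounds are considered here, and "the series" means these few. Any claim that something is new, unique, unknown or untested is made for them only; others in the source may bear on it.

In a physicochemical assay for solubility, using the shake flask method, with a stated time of 12 h (a lower number here means a less soluble compound, a higher number a more soluble compound), compound 1 (`O=C(/C=C/c1ccc(O)c(O)c1)CC(=O)/C=C/c1cccc(O)c1O`) gives 3800 nM and compound 2 (`O=C(/C=C/c1ccccc1O)CC(=O)/C=C/c1cccc(O)c1O`) gives 11000 nM while compound 3 (`O=C(/C=C/c1ccc(O)c(O)c1)CC(=O)/C=C/c1cc(O)ccc1O`) stands highest of the three at 54000 nM on this scale. Compound 4 (`O=C(/C=C/c1cc(O)ccc1O)CC(=O)/C=C/c1cccc(O)c1O`) is not yet measured. It differs from compound 3 by one exchange (2,3-dihydroxyphenyl in place of 3,4-dihydroxyphenyl on a double-bonded chain carbon bound to a double-bonded chain carbon) with 2,3-dihydroxyphenyl in place of 3,4-dihydroxyphenyl. Among the compounds with values here, two steps bear on it. The group 2,3-dihydroxyphenyl left in a large step (a 14-fold higher number from compound 1 to compound 3 (1.15 log units; beyond the scatter)) so its entry here points downward. The group 3,4-dihydroxyphenyl left in a modest step (a 2.9-fold higher number from compound 1 to compound 2 (0.46 log units; beyond the scatter)) that also raised the number, which argues against a fall of full size. A moderate fall in this assay is therefore expected (a 3.0-fold lower number from compound 3 to compound 4 (0.48 log units; beyond the scatter)) here. Compound 4 is estimated at 18000 nM with an expected range from 5000 nM to 60000 nM in this measurement.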

Compound 4, solubility: 100000 nM
Compound 4: middle estimate off by 5.6-fold (0.74 log units), on the low side, outside the stated range (above it).
By their numbers in this assay, from the lowest: compound 1; then compound 2; then compounds 3 and 4 (each within the scatter of the next).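

In this assay, 2,3-dihydroxyphenyl in place of 3,4-dihydroxyphenyl gives a 1.9-fold higher number from compound 3 to compound 4 (0.27 log units; within the scatter), so with 2,5-dihydroxyphenyl present in both compounds, this exchange makes no difference beyond the scatter. Steps of another size appear elsewhere: hydroxy in place of hydrogen on an aromatic carbon gives a 9.1-fold higher number from compound 2 to compound 4 (0.96 log units; beyond the scatter), and 2,5-dihydroxyphenyl in place of 3,4-dihydroxyphenyl gives a 26-fold higher number from compound 1 to compound 4 (1.42 log units; beyond the scatter). No measurement given here accounts for any of these steps. The compounds shown leave open how the number would respond to a methoxy group or an amine in place of one hydroxy on these aromatic rings.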